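A few compounds are considered here, and "the series" means these few. Any claim that something is new, unique, unknown or untested is made for them only; others in the source may bear on it.

- Compound 1 `Cc1cc(=O)c2c(O)cc(OCc3ccccc3)c([C@H]3CCN(C)C[C@H]3O)c2o1`: 18%
- Compound 2 `COc1ccc(COc2cc(O)c3c(=O)cc(C)oc3c2[C@H]2CCN(C)C[C@H]2O)cc1`: 8%

In a functional assay on Caco-2 cells (Homo sapiens) for inhibition, read by MTT assay, with a stated time of 48 h, tested at 10 uM (on this read-out higher numbers stand for more inhibition of growth at the one concentration tested and lower numbers for less inhibition of growth), compound 2 gives 8% and compound 1 gives 18%, two numbers within the scatter of each other. Compound 3 `Cc1cc(=O)c2c(O)cc(OCc3ccc(Br)cc3)c([C@H]3CCN(C)C[C@H]3O)c2o1` differs from compound 2 as follows: bromo in place of methoxy on an aromatic carbon. This is bromo in place of methoxy on an aromatic carbon, para to a large group. Among the compounds with values here, only one measured step bears on this change: a number 10 percentage points lower from compound 1 to compound 2 (within the scatter), with methoxy in place of hydrogen, and it stays within the scatter. The expected change is therefore no larger than the scatter: a number 5 percentage points higher from compound 2 to compound 3 (within the scatter). Compound 3 is estimated at 13%, with an expected range of 2% to 26%.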

Compound 3, percent growth inhibition at one concentration: 13%
Compound 3: middle estimate and measured number agree at the digits printed; the measured number falls inside the stated range.
By their numbers in this assay, from the lowest: compounds 2, 3 and 1 (each within the scatter of the next).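

In this assay, bromo in place of methoxy gives a number 5 percentage points higher from compound 2 to compound 3 (within the scatter), and bromo in place of hydrogen gives a number 5 percentage points lower from compound 1 to compound 3 (within the scatter). A second kind of group on this aromatic carbon, para to a large group, thus also stays within the scatter of compound 1, and the three compounds cannot be ranked. Nothing available gives a reason for these numbers. Open, from the compounds shown here alone, is whether an amine or a carboxylic acid on this carbon would move the number beyond the scatter. Also open, going by these compounds, is what a longer chain in place of the benzyl link would do.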